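Ethyl for Trifluoromethyl on a Dihydropyrimidinone-Like Core

The compounds below may be only part of what the source reports. "The series", "measured", "known", "first", "only" and "open" are said of these compounds alone.

Of the compounds shown here, three have been tested in an assay on HeLa cells for displacement of a labelled ligand from adenosine receptor A3 (Homo sapiens), with a stated time of 180 min, tested at 10 uM; on this read-out lower numbers stand for less inhibition and higher numbers for more inhibition at the one concentration tested (going by the name of the read-out). Compound 1 `CC(=O)C1=C(C)NC(=O)NC1c1ccco1` gives 14%, compound 2 `CC1=C(C(N)=O)C(c2ccco2)NC(=O)N1` gives 2%, and compound 3 `CCOC(=O)C1=C(C(F)(F)F)NC(=O)NC1c1ccco1` gives 2%. For the measured compounds named here, the only measured single change, a number 12 percentage points lower from compound 1 to compound 2 (beyond the scatter), is amino in place of methyl on a carbonyl carbon. Compound 3 therefore stands level with compound 2, the two together lowest of the three, while compound 1 sits higher by a margin beyond the scatter. Compound 4 `CCOC(=O)C1=C(CC)NC(=O)NC1c1ccco1` differs from compound 3 by ethyl in place of trifluoromethyl on a double-bonded ring carbon. Going by the values given here, no measured step touches that double-bonded ring carbon, so the step from compound 1 to compound 2 gives no direct guide. Starting from compound 3 at 2%, a step of a number 4 percentage points higher from compound 3 to compound 4 (within the scatter) is expected, within the scatter. Compound 4 is estimated at 6%, ranging from -8% to 22%.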

Compound 4, a percentage reported as inhibition, at one concentration (the size of the read-out at that concentration, not a potency): 3%
Compound 4: middle estimate off by 3 percentage points, on the high side, and the stated range covers the measured number.
By their numbers in this assay, from the lowest: compounds 2, 3 and 4 (each within the scatter of the next); then compound 1.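

For the compounds shown here, the first change at this double-bonded ring carbon, ethyl in place of trifluoromethyl, gives a number 1 percentage points higher from compound 3 to compound 4 (within the scatter) in this assay. At this single concentration, the two groups therefore cannot be told apart, although ethyl has fewer heavy atoms and no fluorine. No available evidence explains this result. Going by these compounds, it remains open whether an amine, a carboxylic acid or a longer chain on this carbon would give a different number. On these data alone, it is also open whether ethyl and trifluoromethyl would still read alike if the ethoxycarbonyl group were replaced.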